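A few compounds are considered here, and "the series" means these few. Any claim that something is new, unique, unknown or untested is made for them only; others in the source may bear on it.

In a functional assay on MCF7 cells (Homo sapiens) for antiproliferative activity, read by MTT assay, with a stated time of 48 h (on this read-out higher numbers stand for weaker inhibition and lower numbers for stronger inhibition), compound 1 `COc1ccc(-c2c(Nc3ccc(F)cc3)c3ccccc3oc2=O)cc1` gives 38500 nM and compound 3 `COc1ccc(-c2c(Nc3cccc(C(F)(F)F)c3)c3ccc(OC)cc3oc2=O)cc1` gives 36200 nM. For compound 2 `COc1ccc(-c2c(Nc3ccc(F)cc3)c3ccc(OC)cc3oc2=O)cc1` the reading of > 100000 nM is a limit of the assay and not a number. Compound 2 therefore stands as the weakest of the three, with its true value unknown.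

Compound 4 `COc1ccc(-c2c(Nc3ccc(F)cc3)c3ccc(O)cc3oc2=O)cc1` differs from compound 2 by hydrogen in place of methyl on an oxygen on an aromatic ring, with hydrogen in place of methyl on an oxygen on an aromatic ring, turning methoxy to hydroxy. The closest measured change is the one that introduced methoxy in place of hydrogen on an aromatic carbon, which was an at least 2.5-fold higher number from compound 1 to compound 2 (0.41 log units; beyond the scatter). A change elsewhere, on the nitrogen, was an at least 2.7-fold lower number from compound 2 to compound 3 (0.44 log units; beyond the scatter), so compound 2 can be improved from its limit, though that step does not touch the methoxy. Both steps are modest and beyond the scatter. A modest move towards stronger inhibition in this assay is therefore expected, though another limit reading would not surprise. The expected change is an at least 2.0-fold lower number from compound 2 to compound 4 (0.30 log units; that floor lies within the scatter). For compound 4 the estimated value is 50000 nM, with an expected range from 15000 nM to 130000 nM.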

Compound 4, half-maximal inhibitory concentration: 71500 nM
The estimate for compound 4 lay 1.4-fold (0.16 log units) below the measured number, and the stated range covers the measured number.
By their numbers in this assay, from the lowest: compounds 3, 1 and 4 (each within the scatter of the next). At a limit, above all of these: compound 2.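

With hydroxy in place of methoxy on this aromatic ring, this assay gives a number where compound 2 had given only a limit, and the step reads an at least 1.3-fold lower number from compound 2 to compound 4 (0.14 log units; that floor lies within the scatter). Against hydrogen on the same carbon, the step reads a 1.9-fold higher number from compound 1 to compound 4 (0.27 log units; within the scatter) and so hydroxy cannot be told apart from hydrogen here, whereas methoxy gave the reading that stands apart from both. As far as these compounds go, the size of the step from methoxy to hydroxy stays unknown because the reading for compound 2 is a limit of the assay: the limit of > 100000 nM in this assay, at which 1 of the 4 values shown sits.

The compounds shown do not tell whether hydroxy on this ring would combine with the 3-(trifluoromethyl)phenyl on the nitrogen. They also leave open how an amine on this carbon, or a longer chain on this oxygen, would read.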